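The source may hold more compounds than are shown below. What is called first, only, known or untested is meant among the compounds shown, and "the series" means these compounds.

Measured in a functional assay on HeLa cells (Homo sapiens) for inhibition, read by MTT assay, with a stated time of 48 h (on this read-out higher numbers stand for weaker inhibition and lower numbers for stronger inhibition), are three compounds:
Compound 1 `COc1ccc2c(=O)c(/C=C/C(=O)Nc3ccccc3Cl)coc2c1` gives 22400 nM
Compound 2 `COc1ccc2c(=O)c(/C=C/C(=O)Nc3cc(C)ccc3C)coc2c1` gives 58400 nM
Compound 3 `COc1ccc2c(=O)c(/C=C/C(=O)NCc3ccccc3F)coc2c1` gives > 100000 nM as a limit, not a number

Compound 3 stands at the limit of > 100000 nM in this assay, at which 1 of the 3 values shown sits, and so has a limit only. Compound 4 `COc1ccc(NC(=O)/C=C/c2coc3cc(OC)ccc3c2=O)cc1` differs from it by 4-methoxyphenyl in place of 2-fluorobenzyl on an amide-type nitrogen in one place, with 4-methoxyphenyl in place of 2-fluorobenzyl on an amide-type nitrogen. Within the data shown here, two measured steps bear on this change when read in reverse. They are an at least 4.4-fold higher number from compound 1 to compound 3 (0.64 log units; beyond the scatter) and an at least 1.7-fold higher number from compound 2 to compound 3 (0.23 log units; that floor lies within the scatter) and both end at the limit of compound 3. Compound 4 carries a substituted phenyl on that nitrogen, like the two compounds with numbers, and the change between those two is a 2.6-fold higher number from compound 1 to compound 2 (0.42 log units; beyond the scatter) in size. Among the measured compounds shown here, the 4-methoxyphenyl group itself has no measured counterpart, so the range must stay wide. A lower number than that of compound 3 is therefore expected in this assay and would mean stronger inhibition, although another result at the limit remains possible. The expected step is an at least 2.5-fold lower number from compound 3 to compound 4 (0.39 log units; beyond the scatter) on this estimate. For compound 4 the estimated value is 40000 nM with an expected range from 15000 nM to 100000 nM in the same read-out.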

Compound 4, half-maximal inhibitory concentration: 13000 nM
Beside the measured number, compound 4's estimate is 3.1-fold (0.49 log units) above it; the measured number lies below the stated range.
By their numbers in this assay, from the lowest: compounds 4 and 1 (each within the scatter of the next); then compound 2. At a limit, above all of these: compound 3.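

In this assay, among these compounds, 4-methoxyphenyl in place of 2-fluorobenzyl on the amide-type nitrogen gives an at least 7.6-fold lower number from compound 3 to compound 4 (0.88 log units; beyond the scatter), so this position can carry a group of the same heavy-atom count with a clear difference in the read-out, one that the earlier steps could only bound from the other side. Among the three compounds with a phenyl directly on that nitrogen, the result separates 4-methoxyphenyl from 2,5-dimethylphenyl, with a 4.5-fold lower number from compound 2 to compound 4 (0.65 log units; beyond the scatter), but not from 2-chlorophenyl, with a 1.7-fold lower number from compound 1 to compound 4 (0.24 log units; within the scatter), so compound 4 and compound 1 cannot be told apart here. Compound 3 has only a limit and not a number, so its step to compound 4 is a floor: the limit of > 100000 nM in this assay, at which 1 of the 4 values shown sits.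

The compounds shown leave open whether the difference from compound 3 follows the loss of the benzyl methylene link or the presence of the methoxy group, and a 4-methoxybenzyl group on the same nitrogen would separate the two. On these data alone, how an unsubstituted phenyl, a 4-hydroxyphenyl or a 4-aminophenyl group would read at this position also remains open.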